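A few compounds are considered here, and "the series" means these few. Any claim that something is new, unique, unknown or untested is made for them only; others in the source may bear on it.

Of the compounds shown here, three have so far been measured in a functional assay on HOS-TE85 cells (Homo sapiens) for inhibition, read by CCK-8 assay, with a stated time of 72 h; on this read-out lower numbers stand for stronger inhibition and higher numbers for weaker inhibition. Compound 1 `O=C(NCCCCn1cccn1)c1cccc(C2SCC(=O)N2c2ccccn2)c1` gives 60.3 nM. Compound 2 `COc1ccc(C)cc1N1C(=O)CSC1c1cccc(C(=O)NCCCCc2ccccc2)c1` gives 300 nM in this assay, which is the highest of the two numbers shown; compound 1 sits lower, and that gap lies beyond the usual scatter of repeated measurements. For compound 3 `COc1ccccc1N1C(=O)CSC1C(=O)NCCCCc1ccccc1` this assay reports > 1000 nM, a limit rather than a number, and this is the limit of > 1000 nM in this assay, at which 1 of the 3 values shown sits.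

Compound 4 `COc1cc(F)ccc1N1C(=O)CSC1c1cccc(C(=O)NCCCCc2ccccc2)c1` has not yet been measured. It differs from compound 2 in one place: 4-fluoro-2-methoxyphenyl in place of 2-methoxy-5-methylphenyl on an amide-type nitrogen in a ring. The rest of the molecule, including the chain that ends in a phenyl ring and the shared core, is unchanged. Among the compounds with values here, no measured pair in this set shows what such a swap of small groups on this phenyl ring does, so the expectation rests on compound 2 alone. The step of no change at the digits printed from compound 2 to compound 4 (within the scatter) is expected to be small, with no change beyond the scatter in either direction. Compound 4 is therefore expected to give about 300 nM in this assay, most likely between 120 nM and 800 nM.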

Compound 4, half-maximal inhibitory concentration: 71.1 nM
For compound 4 the middle estimate is 4.2-fold (0.63 log units) above the measured one; measured number below the stated range.
By their numbers in this assay, from the lowest: compounds 1 and 4 (each within the scatter of the next); then compound 2. At a limit, above all of these: compound 3.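

The swap of 2-methoxy-5-methylphenyl for 4-fluoro-2-methoxyphenyl on the amide-type nitrogen in the ring gives, in this assay, a 4.2-fold lower number from compound 2 to compound 4 (0.63 log units; beyond the scatter), so the groups on this phenyl ring matter even though the methoxy group and the rest of the molecule stay the same. Within the data shown here, this is the first pair in the set that differs in one place, and so the first direct reading of this position, which the earlier compounds could not give. Nothing measured here explains why the number falls.

This single swap removes a methyl group and adds a fluorine at a different place on the ring, so the two changes cannot be told apart. A 5-fluoro-2-methoxyphenyl or 4-chloro-2-methoxyphenyl group would be needed to show which change counts and whether fluorine itself is required.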